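Removing a methoxy group from a bis-indolyl dibromoquinone

The source may report more compounds than this note shows. Statements on the series, on what has been measured and on what is new or still open speak of the compounds shown alone.

Of the compounds shown here, two have been tested in a functional assay on MDA-MB-231 cells (Homo sapiens) for antiproliferative activity, read by CCK-8 assay, with a stated time of 48 h; a higher number here means a weaker inhibitor, a lower number a stronger inhibitor. Compound 1 `Cc1[nH]c2ccccc2c1C1=C(Br)C(=O)C(Br)=C(c2c(C)[nH]c3ccccc23)C1=O` carries two identical indolyl units on the shared core and gives 4.76 ug/mL. Compound 2 `COc1ccc2[nH]c(C)c(C3=C(Br)C(=O)C(Br)=C(c4c(-c5ccccc5)[nH]c5ccccc45)C3=O)c2c1` bears a methoxy on one indolyl unit and a phenyl on the other; in this assay compound 2 gives 7.67 ug/mL, the higher of the two numbers shown, though the gap to compound 1 lies within the scatter of repeated measurements, so neither compound can be called the stronger inhibitor on these data.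

Compound 3 `Cc1[nH]c2ccccc2c1C1=C(Br)C(=O)C(Br)=C(c2c(-c3ccccc3)[nH]c3ccccc23)C1=O` has not yet been measured. It differs from compound 2 in one place: hydrogen in place of methoxy on an aromatic carbon, which cut one bond further out reads 5-methoxy-2-methyl-1H-indol-3-yl to 2-methyl-1H-indol-3-yl. For the measured compounds named here, no measured pair in the set isolates this change, so the expectation rests on the two values at hand and on the small spread between them. The step from compound 2 to compound 3 is expected to be a 1.2-fold lower number from compound 2 to compound 3 (0.07 log units; within the scatter), not beyond the scatter in either direction. Compound 3 is therefore estimated at 6.5 ug/mL in this assay, within a range from 3.5 ug/mL to 12 ug/mL.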

Compound 3, half-maximal inhibitory concentration: 4.33 ug/mL
Compound 3: the middle estimate sits 1.5-fold (0.18 log units) above what was measured; the range from low to high includes it.
By their numbers in this assay, from the lowest: compounds 3, 1 and 2 (each within the scatter of the next).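

For the compounds shown here, compound 3 gives the first comparisons in this assay that isolate a single change. With hydrogen in place of methoxy on an aromatic carbon of the six-membered ring, turning the 5-methoxy-2-methyl-1H-indol-3-yl unit into 2-methyl-1H-indol-3-yl, the data show a 1.8-fold lower number from compound 2 to compound 3 (0.25 log units; within the scatter), so on this pair the methoxy makes no difference that can be told from repeated measurement. The second comparison, phenyl in place of methyl on an aromatic carbon, shows a 1.1-fold lower number from compound 1 to compound 3 (0.04 log units; within the scatter), so neither single change separates its two compounds in this assay, and nothing measured here speaks to why these numbers lie so close together.

As far as these compounds go, what an amine, a carboxylic acid or a longer alkoxy chain would do on the same aromatic carbon remains open, as only methoxy and hydrogen can be compared there. From the compounds shown here alone, each change is also read on one pair alone, so it remains open whether either would give a similar result with a different group on the other indolyl unit, or in a different cell line.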